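The source may report more compounds than this note shows. Statements on the series, on what has been measured and on what is new or still open speak of the compounds shown alone.

Measured so far in a functional assay on SF-295 cells (Homo sapiens) for inhibition, read by sulforhodamine B assay, with a stated time of 48 h; on this read-out higher numbers stand for lower toxicity in this test and lower numbers for higher toxicity in this test:
compound 1 `O=C(Nc1cccc(-n2cc(-c3ccncc3)c(-c3ccc(Cl)c(O)c3)n2)c1)Nc1cccc(C(F)(F)F)c1`: 29200 nM
compound 2 `COc1cc(-c2nn(-c3cccc(NC(=O)Nc4cccc(C(F)(F)F)c4)c3)cc2-c2ccncc2)ccc1Cl`: 3200 nM
compound 3 `O=C(Nc1cccc(-n2cc(-c3ccncc3)c(-c3ccc(Cl)c(O)c3)n2)c1)Nc1cc(C(F)(F)F)cc(C(F)(F)F)c1`: 4390 nM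

Compound 1 stands highest of the three numbers. Both recorded steps away from it lower the number: a 9.1-fold lower number from compound 1 to compound 2 (0.96 log units; beyond the scatter) and a 6.7-fold lower number from compound 1 to compound 3 (0.82 log units; beyond the scatter). Compound 4 `O=C(Nc1cccc(-n2cc(-c3ccncc3)c(-c3ccc(Cl)c(O)c3)n2)c1)Nc1ccc(Cl)c(C(F)(F)F)c1` differs from compound 1 by chloro in place of hydrogen on an aromatic carbon. Within the data shown here, no measured step covers this exact change. The nearest comparison is the step from compound 1 to compound 3, which also adds a group to the same ring and lowered the number beyond the scatter; a drop of broadly similar size is therefore expected, a 4.9-fold lower number from compound 1 to compound 4 (0.69 log units; beyond the scatter). Compound 4 is estimated at 6000 nM in this assay, with a range from 2000 nM to 20000 nM.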

Compound 4, concentration lethal to 50% of the cells: > 32500 nM
Compound 4 was reported as a limit; the forecaster's own chance of this, stated with the estimate: 5%; at least 5.4-fold (0.73 log units) between middle value and limit.
By their numbers in this assay, from the lowest: compounds 2 and 3 (each within the scatter of the next); then compound 1. At a limit, above all of these: compound 4.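

In this assay, compound 4 is reported only as a limit: the limit of > 32500 nM in this assay, at which 1 of the 4 values shown sits. Chloro on this aromatic carbon, ortho to a trifluoromethyl group, gives an at least 1.1-fold higher number from compound 1 to compound 4 (0.04 log units; that floor lies within the scatter), so the floor of this step does not separate the two compounds, but the number does not come down. A further group on this ring therefore does not lower the number in every case, since a second trifluoromethyl gives a 6.7-fold lower number from compound 1 to compound 3 (0.82 log units; beyond the scatter).

On these data alone, how far the true value of compound 4 lies past its limit stays open. So does whether a fluoro, a methyl or an amine at this same place would behave as chloro does.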